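This account rests on a few compounds, and the source may have more. Where it says the series, first, only, none or still open, it means among the compounds named here.

Of the compounds shown here, three have been measured in an assay for inhibition of serine/threonine-protein kinase PLK2 (Homo sapiens), read by FRET and Z'-LYTE, with a stated time of 1 h; a lower number here means a stronger inhibitor, a higher number a weaker inhibitor. Compound 1, `CCCNS(=O)(=O)c1ccc(Nc2ncc3c(n2)N(C2CCCC2)[C@H](CC)C(=O)N3C)cc1`, gives 17.8 nM. Compound 2, `CC[C@@H]1C(=O)N(C)c2cnc(-n3ccc4cc(C(=O)NC)ccc43)nc2N1C1CCCC1`, gives 8.6 nM, a lower number than compound 1 and a difference beyond the usual scatter. Compound 3, `CCCNC(=O)c1ccc2c(ccn2-c2ncc3c(n2)N(c2ccn(C)n2)C(CC)C(=O)N3C)c1`, gives 207 nM, a much higher number than compound 1, again beyond the scatter. Compound 1 thus stands second highest of the three numbers: closer to compound 2, far from compound 3.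

Compound 4, `CC[C@@H]1C(=O)N(C)c2cnc(Nc3ccc(S(=O)(=O)NC4CCCC4)cc3)nc2N1C1CCCC1`, keeps the shared core of compound 1 and changes only the group on the sulfonamide nitrogen: cyclopentyl in place of propyl on a sulfonamide nitrogen. Going by the values given here, no measured pair differs in just this way, so the size of the step is not anchored by a directly comparable step among the three measured compounds. Compound 1 itself already carries a cyclopentyl ring at another position in its core, and compound 2, which also carries it, gives 8.6 nM, a number in the same low range as compound 1.

The change from compound 1 to compound 4 is therefore expected to leave the number near where compound 1 stands, with a step of a 1.2-fold lower number from compound 1 to compound 4 (0.07 log units; within the scatter), that is, none clearly beyond the scatter. Compound 4 is estimated at 15 nM, with a range from 6 nM to 40 nM.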

Compound 4, half-maximal inhibitory concentration: 23.9 nM
Compound 4: the middle estimate sits 1.6-fold (0.20 log units) below what was measured, and the stated range covers the measured number.
By their numbers in this assay, from the lowest: compound 2; then compounds 1 and 4 (each within the scatter of the next); then compound 3.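

In this assay, going by these compounds alone, cyclopentyl in place of propyl on a sulfonamide nitrogen gives a 1.3-fold higher number from compound 1 to compound 4 (0.13 log units; within the scatter), which is the first direct reading of this position, since no earlier pair differed at this place alone. The group that enters has 5 heavy atoms and a five-membered ring of carbon only, the group that leaves has 3 heavy atoms and no ring, and yet the two numbers stand within the scatter of each other, so for this pair the ring and the extra carbons make no difference that can be read. No separate measurement bears on this result, and the two numbers alone give no explanation for it.

The compounds shown leave open how this sulfonamide nitrogen would respond to groups of a different kind, such as a propyl chain ending in an amine, a carboxylic acid, or a phenyl ring. They also leave open whether the same exchange would read alike on another core, as this single pair sets no pattern beyond compound 1 and compound 4.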